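The source may hold more compounds than are shown below. What is called first, only, known or untested is meant among the compounds shown, and "the series" means these compounds.

Working notes on the series. In a functional assay on SK-BR-3 cells (Homo sapiens) for antiproliferative activity (on this read-out lower numbers stand for stronger inhibition and higher numbers for weaker inhibition), compound 2 (`CC(C)=CCc1cc(C(=O)Nc2cc3ccc(OCCC4CCCCN4)c(C)c3oc2=O)ccc1O`) gives 640 nM, level with compound 1 (`CC(=O)Oc1ccc(C(=O)Nc2cc3ccc(OCCC4CCCCN4)c(C)c3oc2=O)cc1CC=C(C)C`) at 640 nM, and these two share the lowest of the three numbers. Compound 3 (`CC(C)=CCc1cc(C(=O)Nc2cc3ccc(OCC4CCCN(C)C4)c(C)c3oc2=O)ccc1O`) gives 1300 nM.

Compound 4 (`CC(C)=CCc1cc(C(=O)Nc2cc3ccc(OCC4CCN(C)C4)c(C)c3oc2=O)ccc1O`) has not been measured. Its difference from compound 2 is 1-methylpyrrolidin-3-yl in place of (piperidin-2-yl)methyl on a saturated chain carbon bound to an oxygen on an aromatic ring: 1-methylpyrrolidin-3-yl in place of (piperidin-2-yl)methyl, on a saturated chain carbon bound to an oxygen on an aromatic ring.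

Hydrogen in place of acetyl gives no change at the digits printed from compound 1 to compound 2 (within the scatter), but this step lies elsewhere in the molecule and says little here. The relevant precedent is 1-methylpiperidin-3-yl in place of (piperidin-2-yl)methyl at the same place, which gives a 2.0-fold higher number from compound 2 to compound 3 (0.31 log units; beyond the scatter). For the measured compounds named here, no measured compound carries the five-membered ring, so that precedent is only a guide.

A modest move to a higher number is therefore expected in this assay, of similar size to that precedent. The expected step is a 2.0-fold higher number from compound 2 to compound 4 (0.31 log units; beyond the scatter). For compound 4 the estimate is 1300 nM, with an expected range of 500 nM to 3200 nM.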

Compound 4, half-maximal inhibitory concentration: 920 nM
Compound 4: the middle estimate sits 1.4-fold (0.15 log units) above what was measured; measured number inside the range.
By their numbers in this assay, from the lowest: compounds 1, 2, 4 and 3 (each within the scatter of the next, the first and the last beyond it).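

In this assay, the five-membered 1-methylpyrrolidin-3-yl group on a saturated chain carbon bound to an oxygen on an aromatic ring gives a 1.4-fold higher number from compound 2 to compound 4 (0.16 log units; within the scatter), so this position accepts a second ring in place of (piperidin-2-yl)methyl without a step beyond the scatter. Going from the six-membered to the five-membered ring while keeping the methyl on nitrogen gives a 1.4-fold lower number from compound 3 to compound 4 (0.15 log units; within the scatter), so ring size alone shows no resolved effect in this pair. Nothing available explains these steps.

The change from compound 2 to compound 4 alters the ring, its attachment and the nitrogen substituent together, and the compounds shown do not separate these contributions. Also open, on these data alone, is how an unsubstituted pyrrolidin-3-yl, a morpholine ring or an open-chain dimethylamino group would behave at this position.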